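Series notes: chain amine swap going to compound 4

A few compounds are considered here, and "the series" means these few. Any claim that something is new, unique, unknown or untested is made for them only; others in the source may bear on it.

In a functional assay on NCI-H460 cells (Homo sapiens) for cytotoxicity, read by MTT assay, with a stated time of 72 h (a lower number here means a stronger inhibitor, a higher number a weaker inhibitor), compound 1 `COc1cc2c(Oc3ccc(NC(=O)c4nn(-c5ccccc5)c(=O)c5ccccc45)cc3F)ccnc2cc1OCCCN1CCN(C)CC1` gives 450 nM, compound 2 `COc1cc2c(Oc3ccc(NC(=O)c4nn(-c5ccccc5F)c(=O)c5ccccc45)cc3F)ccnc2cc1OCCCN1CCN(C)CC1` gives 230 nM and compound 3 `COc1cc2c(Oc3ccc(NC(=O)c4nn(-c5ccc(Br)cc5)c(=O)c5ccccc45)cc3F)ccnc2cc1OCCCN1CCN(C)CC1` gives 250 nM. Compound 3 stands second highest of the three numbers, with compound 2 nearest and compound 1 furthest, both within the scatter. Compound 4 `COc1cc2c(Oc3ccc(NC(=O)c4nn(-c5ccc(Br)cc5)c(=O)c5ccccc45)cc3F)ccnc2cc1OCCCN1CCCCC1` differs from compound 3 by piperidin-1-yl in place of 4-methylpiperazin-1-yl on a saturated chain carbon, three bonds along the chain from an oxygen on an aromatic ring. Among the compounds with values here, the measured steps of a 2.0-fold lower number from compound 1 to compound 2 (0.29 log units; within the scatter), a 1.8-fold lower number from compound 1 to compound 3 (0.26 log units; within the scatter) and a 1.1-fold higher number from compound 2 to compound 3 (0.04 log units; within the scatter) all concern the phenyl on the aromatic nitrogen; none touches this chain, so no measured step bears on the change. Compound 4 is therefore expected to show a step of no change at the digits printed from compound 3 to compound 4 (within the scatter) in this assay, none beyond the scatter. The estimate for compound 4 is 250 nM, with a range from 110 nM to 600 nM.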

Compound 4, half-maximal inhibitory concentration: 410 nM
Compound 4: the middle estimate sits 1.6-fold (0.21 log units) below what was measured, and the stated range covers the measured number.
By their numbers in this assay, from the lowest: compounds 2, 3, 4 and 1 (each within the scatter of the next).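

Piperidin-1-yl in place of 4-methylpiperazin-1-yl gives a 1.6-fold higher number from compound 3 to compound 4 (0.21 log units; within the scatter) in this assay and is the first measured step at this place on the chain, as the earlier steps all concern the phenyl on the aromatic nitrogen. With the 4-bromophenyl group in place, this chain end therefore tolerates the loss of one ring nitrogen without a step beyond the scatter. Nothing measured here speaks to the reason for this reading.

Going by these compounds, whether the swap reads the same with the 2-fluorophenyl group of compound 2 remains open. Also open, on these data alone, is how morpholin-4-yl or dimethylamino at the chain end, or a butyl chain in place of the propyl, would read.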